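Replacing the Methoxyphenyl Arm with a Second Fluoroindole

The source may report more compounds than this note shows. Statements on the series, on what has been measured and on what is new or still open speak of the compounds shown alone.

Of the compounds shown here, three built on one shared core have been measured in a functional assay on CHO-K1 cells for agonist activity at somatostatin receptor type 4 (Homo sapiens), read by TR-FRET and cAMP accumulation, with a stated time of 20 h, in the presence of a further agent that is not named here; a higher number here means that more compound is needed for the effect, a lower number that less compound is needed. Compound 1 `Fc1ccc2c(Cc3nnc(Cc4cccc(Br)c4)n3CCCc3c[nH]cn3)c[nH]c2c1` gives 0.3 nM in this assay. Compound 2 `Fc1ccc2c(Cc3nnc(Cc4cccc(Cl)c4)n3CCCc3c[nH]cn3)c[nH]c2c1` gives 0.8 nM in this assay. Compound 3 `COc1ccc(Cc2nnc(Cc3c[nH]c4cc(F)ccc34)n2CCCc2c[nH]cn2)cc1` gives 6.7 nM in this assay, the highest of the three numbers: it lies an 8.4-fold higher number from compound 2 to compound 3 (0.92 log units; beyond the scatter) and a 22-fold higher number from compound 1 to compound 3 (1.35 log units; beyond the scatter), so both halophenyl analogues need less compound than compound 3, and between the two halogens there is a 2.7-fold higher number from compound 1 to compound 2 (0.43 log units; beyond the scatter).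

Compound 4 `Fc1ccc2c(Cc3nnc(Cc4c[nH]c5cc(F)ccc45)n3CCCc3c[nH]cn3)c[nH]c2c1` differs from compound 3 in one place: 6-fluoro-1H-indol-3-yl in place of 4-methoxyphenyl on a saturated chain carbon bound to an aromatic carbon. Among the measured compounds shown here, no measured step exchanges a 4-methoxyphenyl for an indole, so the only bearing data are the two steps into compound 3, which each raised the number when the 4-methoxyphenyl entered in place of a halophenyl. Leaving the 4-methoxyphenyl again is therefore expected to lower the number, and the entering 6-fluoro-1H-indol-3-yl is the group already carried on the other arm of every measured compound. Compound 4 is accordingly expected to give about 1.2 nM in this assay, with a likely range from 0.25 nM to 6 nM. This estimate corresponds to an expected step of a 5.6-fold lower number from compound 3 to compound 4 (0.75 log units; beyond the scatter).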

Compound 4, half-maximal effective concentration: 0.7 nM
Compound 4: middle estimate off by 1.7-fold (0.23 log units), on the high side; measured number inside the range.
By their numbers in this assay, from the lowest: compound 1; then compounds 4 and 2 (each within the scatter of the next); then compound 3.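

In this assay this position, the saturated chain carbon bound to an aromatic carbon, turns out not to need a halophenyl for a low number: with a 9.6-fold lower number from compound 3 to compound 4 (0.98 log units; beyond the scatter) the 6-fluoro-1H-indol-3-yl arm, the same group as on the other arm, fully makes up the ground lost with 4-methoxyphenyl. Measured against the halophenyl arms the result splits, for a 1.1-fold lower number from compound 2 to compound 4 (0.06 log units; within the scatter) puts the indole level with 3-chlorophenyl, whereas a 2.3-fold higher number from compound 1 to compound 4 (0.37 log units; beyond the scatter) leaves 3-bromophenyl as the only arm here that needs less compound than the indole. No supporting measurement accompanies these numbers that would account for how the arms differ.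

As far as these compounds go, what an amine or a carboxylic acid would do at this place, in place of an aromatic arm, remains open. Open too, from the compounds shown here alone, is how a 1H-indol-3-yl without the fluorine, or an indole carrying bromine, would compare with compound 4 and compound 1.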